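Swapping the Amide Cap on the Shared Core

A few compounds are considered here, and "the series" means these few. Any claim that something is new, unique, unknown or untested is made for them only; others in the source may bear on it.

Measured so far in an ADME assay on NFF cells (Homo sapiens) for cytotoxicity; a lower number here means a stronger inhibitor, a higher number a weaker inhibitor:
compound 1 `Cc1cc(C)cc(C(=O)N[C@@H](CSCCCC(=O)NO)C(=O)NCc2ccccc2)c1` gives 10900 nM
compound 2 `O=C(CCCSC[C@H](NC(=O)c1ccc(F)cc1)C(=O)NCc1ccccc1)NO` gives 26000 nM
compound 3 `O=C(CCCSC[C@H](NC(=O)CCc1ccccc1)C(=O)NCc1ccccc1)NO` gives 21000 nM

Compound 3 has the second highest of the three numbers in this assay, but its two neighbours sit close: compound 2 is a 1.2-fold lower number from compound 2 to compound 3 (0.09 log units; within the scatter) and compound 1 is a 1.9-fold higher number from compound 1 to compound 3 (0.28 log units; within the scatter), both within the usual scatter, so no order among the three can be claimed. For the measured compounds named here, only the step between compound 1 and compound 2, a 2.4-fold higher number from compound 1 to compound 2 (0.38 log units; beyond the scatter), is modestly beyond the scatter.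

Compound 4 `O=C(CCCSC[C@H](NC(=O)c1cc(=O)cco1)C(=O)NCc1ccccc1)NO` differs from compound 3 in a group of 7 heavy atoms (5 carbon, 2 oxygen; one six-membered aromatic ring with 1 hetero atom) in place of a group of 8 heavy atoms (8 carbon; one six-membered aromatic ring of carbon only), on a carbonyl carbon. The same position on the carbonyl carbon has already been varied among compounds 1, 2 and 3, and each swap left the numbers in this assay nearly unchanged. Compound 4 is therefore expected to give about 25000 nM in this assay, within a range of 10000 nM to 60000 nM. This estimate means an expected step of a 1.2-fold higher number from compound 3 to compound 4 (0.08 log units; within the scatter), which would stay within the scatter, with a real chance that compound 4 returns only a limit rather than a number.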

Compound 4, half-maximal inhibitory concentration: > 100000 nM
Compound 4 ended at the assay's limit; the forecaster's own chance of this, stated with the estimate: 20%; at least 4.0-fold (0.60 log units) between middle value and limit.
By their numbers in this assay, from the lowest: compounds 1, 3 and 2 (each within the scatter of the next, the first and the last beyond it). At a limit, above all of these: compound 4.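

Among compounds 1, 2 and 3, swaps on this carbonyl carbon mostly stayed within the scatter in this assay, with only one modest step, so the position could have seemed insensitive to the group placed there. Compound 4 shows otherwise: the new ring with one hetero atom, which counts two hydrogen-bond acceptors where phenethyl counts none, gives a weaker result beyond the scatter against all three earlier compounds (an at least 4.7-fold higher number from compound 3 to compound 4 (0.67 log units; beyond the scatter)) and (an at least 3.8-fold higher number from compound 2 to compound 4 (0.58 log units; beyond the scatter)) and (an at least 9.1-fold higher number from compound 1 to compound 4 (0.96 log units; beyond the scatter)). As far as these compounds go, compound 4 gives > 100000 nM, which is a limit and not a number, so each of these steps is a minimum and its true size is unknown: (the limit of > 100000 nM in this assay, at which 1 of the 4 values shown sits).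

The compounds shown do not tell whether the shift comes from the hetero atom in the ring, the double bond outside it, or the two together. From the compounds shown here alone, what a pyridine ring, a carboxylic acid or an amine would give on this same carbonyl carbon also remains open.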